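A few compounds are considered here, and "the series" means these few. Any claim that something is new, unique, unknown or untested is made for them only; others in the source may bear on it.

Working notes on the series

Among the compounds with values here, the three measured members share one core and differ only in what hangs from the carbonyl carbon of the amide-type nitrogen. Compound 3 `COc1cc(-c2nn(-c3cccc(NC(=O)Nc4cccc(C(F)(F)F)c4)c3)cc2-c2ccncc2)ccc1Cl` carries a urea arm. In a functional assay on SNB-19 cells (Homo sapiens) for inhibition, read by sulforhodamine B assay, with a stated time of 48 h (on this read-out lower numbers stand for higher toxicity in this test and higher numbers for lower toxicity in this test), compound 3 gives only the limit > 50000 nM, which is a limit of the assay and not a number. Compound 1 `COc1cc(-c2nn(-c3cccc(NC(=O)c4cccc(C(F)(F)F)c4)c3)cc2-c2ccncc2)ccc1Cl` is the corresponding amide. In this assay compound 1 likewise gives the limit > 50000 nM. Compound 2 `COc1cc(-c2nn(-c3cccc(NC(=O)Nc4ccc(Cl)c(Cl)c4)c3)cc2-c2ccncc2)ccc1Cl` is the second urea. In this assay compound 2 again gives the limit > 50000 nM. All three values sit at the limit of > 50000 nM in this assay, at which 3 of the 3 values shown sit, so compound 3 stands level with the other two and no order among them can be read.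

Compound 4 `COc1cc(-c2nn(-c3cccc(NC(=O)c4ccc(Cl)c(C(F)(F)F)c4)c3)cc2-c2ccncc2)ccc1Cl` differs from compound 3 by 4-chloro-3-(trifluoromethyl)phenyl in place of (3-(trifluoromethyl)phenyl)amino on a carbonyl carbon. The measured steps that touch this change are a step that the two limits leave unreadable from compound 1 to compound 3, which runs the amide-to-urea exchange in the opposite direction, and a step that the two limits leave unreadable from compound 2 to compound 3; neither has a readable size because both ends rest at the limit of > 50000 nM in this assay, at which 3 of the 3 values shown sit. Within the data shown here, no measured step therefore supports any movement beyond the scatter in this assay, and none rules it out.

The step from compound 3 to compound 4 is expected to be a step that the limit leaves unreadable from compound 3 to compound 4. Compound 4 is estimated at 60000 nM, within 20000 nM to 200000 nM, most probably reported as a limit.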

Compound 4, concentration lethal to 50% of the cells: > 32500 nM
Compound 4 gave a limit, no number; the forecaster's own chance of this, stated with the estimate: 85%; the middle value does not contradict the limit.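

In this assay compound 4 gives > 32500 nM, which is a limit of the assay and not a number. None of the steps joining compound 4 to compound 1, compound 2 and compound 3 can be read. The compounds shown leave open whether any of these arms on the shared core has a readable value in this assay.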